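The compounds below may be only part of what the source reports. "The series", "measured", "known", "first", "only" and "open" are said of these compounds alone.

The measured compounds in an assay on HEK293 cells for inhibition of N-acylethanolamine-hydrolyzing acid amidase (Rattus norvegicus), read by LC-MS, with a stated time of 30 min; a lower number here means a stronger inhibitor, a higher number a weaker inhibitor:
Compound 1 `Cc1ccc(CCCCCC(=O)N2CCOC2=O)cc1C`, for which compound 1 gives > 20000 nM, a limit of the assay and not a number.
Compound 2 `O=C(CCCCCc1cccc(Br)c1)N1CCOC1=O`, for which compound 2 gives 430 nM.
Compound 3 `O=C(CCCCCc1ccc(F)c(Cl)c1)N1CCOC1=O`, for which compound 3 gives 26 nM.

Among the two numbers actually recorded, compound 2 stands at the higher one, and so is the weaker inhibitor of the pair; compound 3 sits below it by a gap that lies beyond the usual scatter. Compound 1 contributes only a limit, (the limit of > 20000 nM in this assay, at which 1 of the 3 values shown sits), and cannot be ranked against the other two beyond the fact that it gave no number.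

Compound 4 `O=C(CCCCCc1cccc(I)c1)N1CCOC1=O` has not yet been tested in this assay. It differs from compound 2 in one place only: iodo in place of bromo on an aromatic carbon. Going by the values given here, no measured pair in this set differs by a single exchange of one halogen for another, so there is no recorded step on which to lean; compound 3 carries two halogens and a different substitution pattern, and its gap to compound 2 says nothing direct about bromo against iodo. The expected step from compound 2 to compound 4 is therefore small, a 1.2-fold lower number from compound 2 to compound 4 (0.09 log units; within the scatter), with a slight lean toward a lower number but not clearly beyond the scatter. On that basis compound 4 is estimated at 350 nM, within a range from 120 nM to 1100 nM.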

Compound 4, half-maximal inhibitory concentration: 3120 nM
For compound 4 the middle estimate is 8.9-fold (0.95 log units) below the measured one; measured number outside the range, above it.
By their numbers in this assay, from the lowest: compound 3; then compound 2; then compound 4. At a limit, above all of these: compound 1.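

In this assay, the exchange of one halogen for another on an aromatic carbon, meta to a large group, proves far from silent: iodo in place of bromo gives a 7.3-fold higher number from compound 2 to compound 4 (0.86 log units; beyond the scatter). The earlier compounds shown here could not show this, since none of them formed a pair differing in one place, whereas here a single heavy atom is exchanged with the rest of the structure held fixed, and the number still moves beyond the scatter. The result shows that this position distinguishes between bromo and iodo, with the bromo of compound 2 giving the stronger inhibitor of this pair, but nothing given here bears on why the two halogens differ.

On these data alone, it remains open how chloro, fluoro, methyl or trifluoromethyl at this same place would stand against bromo and iodo, and so whether the numbers follow any order across such groups. Also open, as far as these compounds go, is whether the same exchange would carry the same size of step on a shorter or longer chain, or at another place on the ring.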